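The compounds below may be only part of what the source reports. "The series", "measured", "known", "first", "only" and "open" are said of these compounds alone.

Measured so far:
Compound 1, `COc1ccc(C(c2ccc(OC)cc2)N2CCN(C(=O)COc3ccc4ccccc4c3)CC2)cc1`: 25.6%
Compound 2, `COc1ccc(OCC(=O)N2CCN(C(c3ccc(F)cc3)c3ccc(F)cc3)CC2)cc1`: 80.5%

Both compounds were tested in a functional assay on PC-12 cells (Rattus norvegicus) for cytotoxicity, read by MTT assay, with a stated time of 24 h, tested at 10 uM; on this read-out lower numbers stand for a weaker effect and higher numbers for a stronger effect at the one concentration tested. Compound 2 gives 80.5%, the higher of the two numbers. Compound 1 gives 25.6%, and the gap between the two lies well beyond the usual scatter of repeated measurements, so compound 2 clearly stands as the stronger of the pair on this read-out.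

Compound 3, `COc1ccccc1OCC(=O)N1CCN(C(c2ccc(F)cc2)c2ccc(F)cc2)CC1`, has not yet been measured. It differs from compound 2 in a single respect: 2-methoxyphenyl in place of 4-methoxyphenyl on an oxygen on a saturated carbon. The two compounds contain exactly the same atoms, joined differently, so the change amounts to a rearrangement of one substituent rather than the addition or removal of anything.

Among the compounds with values here, no pair of measured compounds differing in one place is available, so there is no measured step to lean on. Given that the shared core of compound 2 is kept intact and only the methoxy group changes place, compound 3 is expected to stay close to compound 2, with a small downward drift as the more likely direction. The expected step from compound 2 to compound 3 is a number 10.5 percentage points lower from compound 2 to compound 3 (beyond the scatter), a change that may still fall within the scatter. Compound 3 is therefore estimated at 70%, within a range from 45% to 90%.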

Compound 3, a percentage reported as activity, at one concentration (the size of the read-out at that concentration, not a potency): 79.7%
Estimate against measurement, compound 3: 9.7 percentage points below; measured number inside the range.
By their numbers in this assay, from the lowest: compound 1; then compounds 3 and 2 (each within the scatter of the next).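

In this assay, the swap of 2-methoxyphenyl in place of 4-methoxyphenyl on an oxygen on a saturated carbon gives a number 0.8 percentage points lower from compound 2 to compound 3 (within the scatter) and so does not separate the two compounds. Within the data shown here, this is the first direct comparison in which only one place differs, and it shows that, for this pair, the high read-out does not depend on which of these two methoxyphenyl groups is present. Compound 1 differs from both compounds in more than one place, so it cannot show what this single change does, and no measurement available here explains why the swap leaves the two compounds indistinguishable.

The result covers only these two methoxyphenyl groups on the shared core, so it cannot predict what would happen if the methoxy group were replaced by an amine or a carboxylic acid. Nor does it show whether a longer chain between the oxygen and the amide carbonyl would leave the read-out just as unchanged.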